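A few compounds are considered here, and "the series" means these few. Any claim that something is new, unique, unknown or untested is made for them only; others in the source may bear on it.

Compound 1 `CC[C@H](C)[C@H](NC(=O)CN(c1nc(Cl)nc2[nH]cnc12)C1CC1)C(=O)O` gives 27.4% in a functional assay on the whole organism (Tail, strain ICR) with Mus musculus as the target, in the tail flick test, with a stated time of 90 min, at a dose of 25 umol/kg by the oral route; on this read-out lower numbers stand for a weaker effect and higher numbers for a stronger effect at the one dose given. Compound 2 `CC[C@H](C)[C@H](NC(=O)CN(c1ncnc2c1ncn2C1CCCCO1)C1CC1)C(=O)OCc1ccccc1` gives 22.6% in this assay; numerically this is the smaller of the two numbers, but the gap to compound 1 lies within the scatter, so no real order between them is shown. Compound 3 `N=C(N)NCCC[C@H](NC(=O)CN(c1ncnc2c1ncn2C1CCCCO1)C1CC1)C(=O)OCc1ccccc1` differs from compound 2 in one place: a group of 7 heavy atoms (4 carbon, 3 nitrogen; no ring) in place of a group of 4 heavy atoms (4 carbon; no ring), on a saturated chain carbon bound to an amide-type nitrogen and a carbonyl carbon. Within the data shown here, no step between measured compounds is known, so there is no basis for expecting a direction, and the estimated step is a number 2.4 percentage points higher from compound 2 to compound 3 (within the scatter), none beyond the scatter. Compound 3 is expected to give 25% in this assay, estimated between 10% and 45%.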

Compound 3, a percentage reported as activity, at one dose (the size of the read-out at that dose, not a potency): 61.6%
Compound 3: the middle estimate sits 36.6 percentage points below what was measured, outside the stated range (above it).
By their numbers in this assay, from the lowest: compounds 2 and 1 (each within the scatter of the next); then compound 3.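

In this assay, the saturated chain carbon bound to an amide-type nitrogen and a carbonyl carbon proves sensitive to its substituent: replacing sec-butyl with the group of 7 heavy atoms gives a number 39 percentage points higher from compound 2 to compound 3 (beyond the scatter). Among these compounds, this is the first one-place change read, so it is the first evidence that this position can shift the read-out. Nothing on hand accounts for the step.

As far as these compounds go, it remains open whether the gain follows the nitrogen atoms of the entering group or its chain alone. A plain butyl chain or a chain ending in a primary amine at this position would separate the two.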